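A few compounds are considered here, and "the series" means these few. Any claim that something is new, unique, unknown or untested is made for them only; others in the source may bear on it.

The study concerns a small set of compounds built on a shared core, all tested in a functional assay on cells (Cancer cell lines, Homo sapiens) for cytotoxicity, read by sulforhodamine B assay, with a stated time of 48 h; a lower number here means a stronger inhibitor of growth, a higher number a weaker inhibitor of growth. Compound 1, with the structure `COc1ccc(C2=NN(C3=NC(=O)/C(=C4\C(=O)Nc5ccccc54)S3)C(c3ccc(OC)cc3)C2)cc1`, gives 100000 nM in this assay. Compound 2, with the structure `COc1ccc(C2=NN(C3=NC(=O)/C(=C4\C(=O)Nc5ccc(Br)cc54)S3)C(c3ccc(OC)cc3)C2)cc1`, carries the change bromo in place of hydrogen on an aromatic carbon and gives 710 nM in this assay. Going by the values given here, the step of a 140-fold lower number from compound 1 to compound 2 (2.15 log units; beyond the scatter) is the one counted change between measured compounds in this set.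

Compound 3, with the structure `CN(C)c1ccc(C2CC(c3ccccc3)=NN2C2=NC(=O)/C(=C3\C(=O)Nc4ccccc43)S2)cc1`, gives 34000 nM in this assay. The difference between the core of compound 3 and the core of compound 1 is not broken down here; the two values alone show that compound 3 sits between compound 1 and compound 2.

Compound 4, with the structure `CN(C)c1ccc(C2CC(c3ccccc3)=NN2C2=NC(=O)/C(=C3\C(=O)Nc4ccc(Br)cc43)S2)cc1`, has not yet been measured. It differs from compound 3 by bromo in place of hydrogen on an aromatic carbon, a change that occurs twice among these compounds and is the same change as that from compound 1 to compound 2, placed in the same words. Among the compounds with values here, from compound 3 to compound 4 the step is expected to be a 23-fold lower number from compound 3 to compound 4 (1.36 log units; beyond the scatter), somewhat smaller than the one step already seen, because only the single step of a 140-fold lower number from compound 1 to compound 2 (2.15 log units; beyond the scatter) supports it and it rests on one pair. Compound 4 is therefore estimated at 1500 nM in this assay. For compound 4 the expected range runs from 300 nM to 10000 nM.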

Compound 4, concentration for total growth inhibition: 720 nM
Compound 4: the middle estimate sits 2.1-fold (0.32 log units) above what was measured, and the stated range covers the measured number.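

In this assay bromo in place of hydrogen on an aromatic carbon gives a 47-fold lower number from compound 3 to compound 4 (1.67 log units; beyond the scatter) and so again lowers the number, as it did on the core of compound 1. The direction of the change therefore carries over from one core to the other, and it is large on both, but its size does not carry over unchanged, since the two steps lie further apart than the scatter allows: the same change on two cores in this assay, a 140-fold lower number (2.15 log units; beyond the scatter) from compound 1 to compound 2 and a 47-fold lower number (1.67 log units; beyond the scatter) from compound 3 to compound 4, 3.0-fold (0.47 log units) apart, beyond the scatter of two such steps. Going by these compounds alone, these are only two pairs, so they do not show how the change would behave on any further core, and they do not explain why its size differs between the two.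

Only hydrogen and bromo appear at this place on the six-membered aromatic ring, which leaves open what a chloro group, a fluoro group, a nitrile or an amine would give there. Going by these compounds, it also remains open whether a carboxylic acid or a longer chain elsewhere on these compounds would alter the size of the step seen with bromo.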